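The source may hold more compounds than are shown below. What is called first, only, known or untested is meant among the compounds shown, and "the series" means these compounds.

Compound 3, `COC(=O)/C=C/c1cccc(N(Cc2ccccc2)C(=O)C2CCCCC2)c1`, is built from a cinnamate ester on one aromatic ring, an amide of cyclohexanecarboxylic acid, and a benzyl group on the amide-type nitrogen. In an assay on isolated protein with Bile acid receptor (Homo sapiens) as the target (on this read-out higher numbers stand for an effect only at larger amounts of compound and lower numbers for an effect already at smaller amounts), compound 3 gives > 1000 nM, which is a limit of the assay rather than a measured number. Compound 2, `COC(=O)/C=C/c1cccc(NC(=O)C2CCCCC2)c1`, has hydrogen on that nitrogen instead of benzyl; in this assay compound 2 gives > 1000 nM, again a limit. The step that the two limits leave unreadable from compound 2 to compound 3 is therefore not readable, since both values sit at the limit of > 1000 nM in this assay, at which 2 of the 3 values shown sit. Compound 1, `COC(=O)/C=C/c1cccc(N(Cc2ccc(-c3ccc(OC)cc3)cc2)C(=O)C2CCCCC2)c1`, carries 4-methoxyphenyl on an aromatic carbon of the benzyl group, and in this assay compound 1 gives 89 nM. The step of an at least 11-fold higher number from compound 1 to compound 3 (1.05 log units; beyond the scatter) shows that removing a group from an aromatic carbon of the benzyl ring costs a great deal.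

Compound 4, `COC(=O)/C=C/c1cccc(N(Cc2ccc(/C=C/C(=O)O)cc2)C(=O)C2CCCCC2)c1`, differs from compound 3 by 2-carboxyethenyl in place of hydrogen on an aromatic carbon. Among the compounds with values here, no measured step covers this exact change; the step of an at least 11-fold higher number from compound 1 to compound 3 (1.05 log units; beyond the scatter) is the only one that bears on it, and it suggests that a group on that aromatic carbon matters. A gain is expected, estimated as an at least 4.0-fold lower number from compound 3 to compound 4 (0.60 log units; beyond the scatter). Compound 4 is expected to give about 250 nM in this assay, within a range of 60 nM to 1500 nM.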

Compound 4, half-maximal effective concentration: > 1000 nM
Compound 4 ended at the assay's limit (the forecaster's own chance of this, stated with the estimate: 30%); at least 4.0-fold (0.60 log units) between middle value and limit.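

Putting just any group on the aromatic carbon para to a large group is not enough: with 2-carboxyethenyl in place of 4-methoxyphenyl, this assay shows an at least 11-fold higher number from compound 1 to compound 4 (1.05 log units; beyond the scatter). Of the two groups seen at this position, only 4-methoxyphenyl brings the value down to a measurable number, so the earlier gain belongs to that group and not simply to having something there. Whether 2-carboxyethenyl does anything at all compared with hydrogen cannot be read, because neither compound 3 nor compound 4 gives a number beyond the limit: the limit of > 1000 nM in this assay, at which 3 of the 4 values shown sit.

The compounds shown leave open which part of 4-methoxyphenyl matters, since a plain phenyl and a lone methoxy group on that carbon are not among them. They also leave open how an amine or a longer carbon chain would behave there.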